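The source may hold more compounds than are shown below. What is called first, only, known or untested is meant among the compounds shown, and "the series" means these compounds.

Series notes, clearance step from compound 2 to compound 4.

In an ADME assay on microsomes from liver (Mus musculus, strain CD1) for metabolic stability, read by HPLC, using NADPH, with a stated time of 30 min, tested at 0.5 uM (a lower number here means slower removal, a higher number faster removal of the compound), compound 1 `CC(=O)Nc1cnc2[nH]c(=O)n([C@H]3CC[C@H](C(C)(C)C)CC3)c(=O)c2c1` gives 1.4 mL.min-1.g-1. Compound 2 `CC(=O)Nc1cnc2[nH]c(=O)n([C@H]3CC[C@@H](C(C)(C)C)CC3)c(=O)c2c1` gives 15 mL.min-1.g-1 and so stands highest of the three numbers in this assay, with compound 1 nearest and compound 3 furthest. Compound 3 `CC[C@H]1CC[C@H](n2c(=O)[nH]c3ncc(NC(C)=O)cc3c2=O)CC1` gives 0.5 mL.min-1.g-1.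

Two measured steps frame the question. The first, an 11-fold higher number from compound 1 to compound 2 (1.03 log units; beyond the scatter), is a large move that rests on the fact that compounds 1 and 2 differ only in the configuration as drawn alone. The second, a 2.8-fold lower number from compound 1 to compound 3 (0.45 log units; beyond the scatter), is the same exchange of side group that is now to be made from compound 2.

Compound 4 `CC[C@H]1CC[C@@H](n2c(=O)[nH]c3ncc(NC(C)=O)cc3c2=O)CC1` is not yet measured in this assay. Against compound 2 the change is ethyl in place of tert-butyl on a saturated ring carbon. Within the data shown here, compound 4 therefore stands to compound 2 as compound 3 stands to compound 1, and the only measured guide for the exchange is the modest downward step a 2.8-fold lower number from compound 1 to compound 3 (0.45 log units; beyond the scatter). Its size is taken as the expectation here, applied to the higher starting number of compound 2; a step of about the same size, downward and beyond the scatter, is expected, that is a 2.7-fold lower number from compound 2 to compound 4 (0.44 log units; beyond the scatter).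

On that basis compound 4 is estimated at 5.5 mL.min-1.g-1 in this assay, with a range from 2.5 mL.min-1.g-1 to 12 mL.min-1.g-1.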

Compound 4, intrinsic clearance in microsomes: 2.7 mL.min-1.g-1
For compound 4 the middle estimate is 2.0-fold (0.31 log units) above the measured one; the measured number falls inside the stated range.
By their numbers in this assay, from the lowest: compound 3; then compounds 1 and 4 (each within the scatter of the next); then compound 2.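

In this assay, ethyl in place of tert-butyl on a saturated ring carbon also lowers the number in the second configuration, a 5.6-fold lower number from compound 2 to compound 4 (0.74 log units; beyond the scatter), so the direction of this exchange now holds for both configurations and the sizes of the two steps cannot be told apart: the same change on two cores in this assay, a 2.8-fold lower number (0.45 log units; beyond the scatter) from compound 1 to compound 3 and a 5.6-fold lower number (0.74 log units; beyond the scatter) from compound 2 to compound 4, 2.0-fold (0.30 log units) apart, within the scatter of two such steps. The effect of configuration also persists with the smaller ethyl group, a 5.4-fold higher number from compound 3 to compound 4 (0.73 log units; beyond the scatter), which goes the same way as the tert-butyl pair, an 11-fold higher number from compound 1 to compound 2 (1.03 log units; beyond the scatter), and this new step can be assigned to configuration alone: the fact that compounds 3 and 4 differ only in the configuration as drawn. Across these four compounds, each of the two changes points the same way both times it can be read, and no compound shown goes against either pattern.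

With only tert-butyl and ethyl at this ring carbon, the compounds shown cannot tell whether the number keeps falling with a methyl group, or how a hydroxyl group or an amine in the same place would behave in either configuration. They also leave open what underlies the gap between the two configurations, and whether it would persist with such groups.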